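Ester to Acid on the Chain of Compound 3

A few compounds are considered here, and "the series" means these few. Any claim that something is new, unique, unknown or untested is made for them only; others in the source may bear on it.

Measured so far in an assay on isolated protein for inhibition of protein deacetylase HDAC6 (Homo sapiens), read by fluorescence, tested at 1 uM; on this read-out lower numbers stand for less inhibition and higher numbers for more inhibition at the one concentration tested (going by the name of the read-out):
compound 1 `CC(C)(C)OC(=O)N[C@@H](CCCCS)C(=O)NC1CCCC1` gives 50%
compound 2 `O=C(O)CCCC[C@H](NC(=O)OCc1ccccc1)C(=O)NC1CCCC1` gives 20%
compound 3 `COC(=O)CCCCC[C@H](NC(=O)OCc1ccccc1)C(=O)NC1CCCC1` gives 65%

Compound 3 stands highest of the three numbers in this assay; compound 1 sits nearer to it and compound 2 furthest, both gaps beyond the scatter. Compound 4 `O=C(O)CCCCC[C@H](NC(=O)OCc1ccccc1)C(=O)NC1CCCC1` differs from compound 3 by hydrogen in place of methyl on an oxygen next to a carbonyl group. Going by the values given here, the one measured step that bears on this is a number 45 percentage points higher from compound 2 to compound 3 (beyond the scatter), in which carboxy gave way to (methoxycarbonyl)methyl; compound 4 reverses the methoxycarbonyl-to-carboxy part of that exchange. Because of a number 45 percentage points higher from compound 2 to compound 3 (beyond the scatter) a step downward, beyond the scatter, is expected for compound 4, of about a number 40 percentage points lower from compound 3 to compound 4 (beyond the scatter). Compound 4 is therefore estimated at 25%, with a range from 5% to 50%.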

Compound 4, a percentage reported as inhibition, at one concentration (the size of the read-out at that concentration, not a potency): 40%
For compound 4 the middle estimate is 15 percentage points below the measured one; low and high end bracket the measured number.
By their numbers in this assay, from the lowest: compound 2; then compounds 4 and 1 (each within the scatter of the next); then compound 3.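

In this assay the change of methoxycarbonyl to carboxy alone gives a number 25 percentage points lower from compound 3 to compound 4 (beyond the scatter) and so accounts for only part of the earlier gap between the ester and the shorter acid. Carboxymethyl in place of carboxy gives a number 20 percentage points higher from compound 2 to compound 4 (beyond the scatter) and so shows that the two acids differ from each other, a part the earlier compounds had left joined to the ester change. Nothing at hand gives a cause for either step.

As far as these compounds go, whether a hydroxamic acid or a primary amide at the chain end would read like the ester or like the acid stays open. So does the effect of a still longer chain.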